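A Shared Core, Four Different Aryl Groups

This account rests on a few compounds, and the source may have more. Where it says the series, first, only, none or still open, it means among the compounds named here.

Compound 1 `N#Cc1ccc(/C=N/NC(=O)Nc2ccc(Oc3ccnc4[nH]ccc34)c(F)c2)cc1` was tested in a functional assay on MCF7 cells (Homo sapiens) for antiproliferative activity, read by MTT assay, with a stated time of 72 h; a higher number here means a weaker inhibitor, a lower number a stronger inhibitor. In this assay compound 1 gives "not active" (no number reported), so no single number stands for it. Two relatives built on the same core have numbers: compound 2 `COc1cc(/C=N/NC(=O)Nc2ccc(Oc3ccnc4[nH]ccc34)c(F)c2)cc(OC)c1OC` gives 21900 nM in this assay, and compound 3 `CC(C)(C)c1cc(/C=N/NC(=O)Nc2ccc(Oc3ccnc4[nH]ccc34)c(F)c2)cc(C(C)(C)C)c1O` gives 840 nM. Compound 4 `O=C(N/N=C/c1ccc(O)c(Br)c1)Nc1ccc(Oc2ccnc3[nH]ccc23)c(F)c1` is not yet measured. It differs from compound 1 in one place: 3-bromo-4-hydroxyphenyl in place of 4-cyanophenyl on a carbon with a double bond to nitrogen. Since compound 1 gives "not active" (no number reported) in this assay, any measurable number for compound 4 would be a step toward activity; a move well beyond the scatter, in the direction of a stronger inhibitor, is expected. For compound 4 a value of 6000 nM is estimated, within a range from 1000 nM to 35000 nM.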

Compound 4, half-maximal inhibitory concentration: 8230 nM
The estimate for compound 4 lay 1.4-fold (0.14 log units) below the measured number; low and high end bracket the measured number.
By their numbers in this assay, from the lowest: compound 3; then compound 4; then compound 2.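

In this assay, going by these compounds alone, compound 1 has no number, so no step to compound 4 can be read. Which part of the 3-bromo-4-hydroxyphenyl group in compound 4 matters stays open. Nothing shown here explains the result.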